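This account rests on a few compounds, and the source may have more. Where it says the series, first, only, none or still open, it means among the compounds named here.

Measured in a functional assay on CWR22R cells (Homo sapiens) for antiproliferative activity, read by colorimetric assay and sulforhodamine B assay, with a stated time of 72 h; on this read-out lower numbers stand for stronger inhibition and higher numbers for weaker inhibition:
- compound 1 `Oc1noc2cccc(Nc3cccc(C(F)(F)F)c3)c12`: 64800 nM
- compound 2 `O=[N+]([O-])c1cccc(Nc2cccc3onc(O)c23)c1`: > 100000 nM (a limit, not a number)

Compound 2 stands at the limit of > 100000 nM in this assay, at which 1 of the 2 values shown sits, so its true value is not known. Moving on to compound 3 `Oc1noc2cccc(Nc3cccc(S(F)(F)(F)(F)F)c3)c12`, the change is a group of 6 heavy atoms (5 fluorine, 1 sulfur; no ring) in place of a group of 3 heavy atoms (1 nitrogen, 2 oxygen; no ring), on an aromatic carbon: a group of 6 heavy atoms (5 fluorine, 1 sulfur; no ring) takes the place of the nitro, on an aromatic carbon.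

Going by the values given here, the only measured step that bears on this is an at least 1.5-fold higher number from compound 1 to compound 2 (0.18 log units; that floor lies within the scatter). It swaps trifluoromethyl and nitro at the same place, and it gives no clear separation. Compound 3 again carries a fluorine-bearing group there, so a reading near compound 1 at 64800 nM is expected in this assay, a modest move towards lower numbers. The expected size of this move is an at least 2.0-fold lower number from compound 2 to compound 3 (0.30 log units; that floor lies within the scatter). For compound 3 the estimated value is 50000 nM, with an expected range of 20000 nM to 100000 nM.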

Compound 3, half-maximal inhibitory concentration: 64900 nM
Estimate against measurement, compound 3: 1.3-fold (0.11 log units) below; measured number inside the range.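

In this assay, this position accepts a group of 6 heavy atoms (5 fluorine, 1 sulfur) in place of trifluoromethyl with no clear separation: a 1.0-fold higher number from compound 1 to compound 3 (0.00 log units; within the scatter). Compound 1 alone could not show that these two fluorine-bearing groups read alike, and here a group with more heavy atoms leaves the number within the usual scatter. The other new step, an at least 1.5-fold lower number from compound 2 to compound 3 (0.18 log units; that floor lies within the scatter), gives no clear separation either, since its starting point is a limit and not a number: the limit of > 100000 nM in this assay, at which 1 of the 3 values shown sits.

Going by these compounds, whether any group at this position can bring a clearly lower number in this assay stays open. An amine, a carboxylic acid or a single chlorine atom there would test whether the read-out moves at all with a group free of fluorine.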